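The source may report more compounds than this note shows. Statements on the series, on what has been measured and on what is new or still open speak of the compounds shown alone.

Of the compounds shown here, three have so far been measured in a functional assay on CHO-K1 cells for agonist activity at Glucose-dependent insulinotropic receptor (Homo sapiens), read by a luciferase reporter, with a stated time of 5 h; on this read-out lower numbers stand for an effect already at smaller amounts and higher numbers for an effect only at larger amounts of compound. Compound 1 `CC(C)OC(=O)N1CCC(Oc2cccc3c2CCN3c2ccc(S(C)(=O)=O)cc2F)CC1` gives 1000 nM. Compound 2 `CC(C)OC(=O)N1CCC(Oc2ncnc3c2CCN3c2ccc(-c3nccs3)cc2F)CC1` gives 79.4 nM. Compound 3 `CC(C)COC(=O)N1CCC(Oc2ncnc3c2CCN3c2ccc(S(C)(=O)=O)cc2F)CC1` gives 25.1 nM, the lowest of the three numbers; compound 2 stands a step beyond the scatter above it, and compound 1 lies further still. No two of these three compounds differ in only one place, so no single structural change can be read off from their values.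

Compound 4 `CS(=O)(=O)c1ccc(N2CCc3c(OC4CCN(C5=NCCCN5)CC4)ncnc32)c(F)c1` has not yet been measured. It differs from compound 3 in one place: a group of 6 heavy atoms (4 carbon, 2 nitrogen; one six-membered non-aromatic ring with 2 hetero atoms) in place of a group of 7 heavy atoms (5 carbon, 2 oxygen; no ring), on an amine nitrogen in a ring. The isobutoxycarbonyl that leaves has no ring and no hydrogen-bond donor; the group that enters brings one six-membered non-aromatic ring with 2 hetero atoms and 1 hydrogen-bond donor, sitting on an amine nitrogen in a ring. Among the compounds with values here, none of the measured compounds shows a change of this kind, and all three carry a chain of the leaving kind at that position, so the size of the step is uncertain. Compound 4 is expected to give a higher number than compound 3, with a step of a 10-fold higher number from compound 3 to compound 4 (1.00 log units; beyond the scatter) that goes beyond the scatter. Compound 4 is estimated at 250 nM, within a range from 50 nM to 1250 nM.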

Compound 4, half-maximal effective concentration: 2000 nM
Beside the measured number, compound 4's estimate is 8.0-fold (0.90 log units) below it, outside the stated range (above it).
By their numbers in this assay, from the lowest: compound 3; then compound 2; then compounds 1 and 4 (each within the scatter of the next).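

Within the data shown here, the first comparison in which only one place differs shows that this position is far from indifferent: in this assay, replacing the isobutoxycarbonyl on the amine nitrogen in a ring with the six-membered non-aromatic ring with 2 hetero atoms gives an 80-fold higher number from compound 3 to compound 4 (1.90 log units; beyond the scatter). The earlier compounds shown here could not show this, as all three carry a chain of the isobutoxycarbonyl kind at this position and no two differ in only one place. The shared remainder of compound 3 and compound 4 is therefore not enough to keep the low number, and what sits on this nitrogen matters greatly, though no measurement here explains why the number rises so steeply.

The compounds shown leave open which part of the change counts, since the ring, the hydrogen-bond donor and the swap of the two oxygen atoms for two nitrogen atoms all arrive together. A simple acetyl, a longer carbamate chain such as pentyloxycarbonyl, or a six-membered ring without the hydrogen-bond donor on the same nitrogen would each test a different part of that question.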